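The source may report more compounds than this note shows. Statements on the series, on what has been measured and on what is new or still open speak of the compounds shown alone.

Compounds measured in an assay on isolated protein with dual specificity calcium/calmodulin-dependent 3',5'-cyclic nucleotide phosphodiesterase 1B (Bos taurus) as the target, tested at 100 uM; on this read-out lower numbers stand for less inhibition and higher numbers for more inhibition at the one concentration tested (going by the name of the read-out):
compound 1, `Nc1nc2c(c(=O)n(CC3CC3)c(=O)n2CC2CC2)n1S(=O)(=O)c1ccc(Cl)cc1`, gives 1%;
compound 2, `COc1ccc(S(=O)(=O)n2c(N)nc3c2c(=O)n(CC2CC2)c(=O)n3CC2CC2)cc1OC`, gives 56%.

Within the data shown here, compound 2 stands highest of the two numbers; the nearest, and only other, is compound 1, and the step of a number 55 percentage points higher from compound 1 to compound 2 (beyond the scatter) is the single measured step, a large one. Compound 3, `Nc1nc2c(c(=O)n(CC3CC3)c(=O)n2CC2CC2)n1S(=O)(=O)c1ccc([N+](=O)[O-])cc1`, is not yet measured. The change is 4-nitrophenyl in place of 3,4-dimethoxyphenyl on a sulfonyl sulfur. Among the measured compounds shown here, only the step from compound 1 to compound 2 bears on it, and it shows that swapping the group on the sulfonyl sulfur can move the number a long way. For compound 3 a fall toward the level of compound 1 is expected, a number 36 percentage points lower from compound 2 to compound 3 (beyond the scatter). Compound 3 is estimated at 20%, ranging from 0% to 55%.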

Compound 3, a percentage reported as inhibition, at one concentration (the size of the read-out at that concentration, not a potency): 14%
For compound 3 the middle estimate is 6 percentage points above the measured one, and the stated range covers the measured number.
By their numbers in this assay, from the lowest: compound 1; then compound 3; then compound 2.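

In this assay, the result of a number 42 percentage points lower from compound 2 to compound 3 (beyond the scatter) shows that the low reading of the 4-chlorophenyl compound is not unique to that group, since 4-nitrophenyl on the sulfonyl sulfur also stays far under 3,4-dimethoxyphenyl. The result of a number 13 percentage points higher from compound 1 to compound 3 (beyond the scatter) adds that nitro in place of chloro on an aromatic carbon still separates the two low compounds, by a much smaller margin. Nothing available accounts for either difference.

Open, as far as these compounds go, is whether one methoxy alone would hold the number reached with 3,4-dimethoxyphenyl. Also open, from the compounds shown here alone, is how an unsubstituted phenyl or a methyl on the sulfonyl sulfur would read.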